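From methylamino to anilino on a weak inhibitor

This account rests on a few compounds, and the source may have more. Where it says the series, first, only, none or still open, it means among the compounds named here.

In a functional assay on L02 cells (Homo sapiens) for inhibition, read by Griess assay, with stated times of 1 h and 24 h (a higher number here means a weaker inhibitor, a lower number a stronger inhibitor), compound 2 `CNc1nc(/C=C/c2ccccc2)nc2ccsc12` gives > 1000000 nM, which is a limit and not a number. Compound 1 `CCCc1nn(C)c2c(NCc3ccc(F)cc3)nc(CCc3cccnc3)nc12` gives < 40000 nM, and this is also a limit. For the measured compounds named here, these are the only two readings available, so compound 2 has no exact value to be compared with. Going by the values given here, no two measured compounds differ in one place only, so no measured step gives a size to work from.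

Compound 3 `C(=C/c1nc(Nc2ccccc2)c2sccc2n1)\c1ccccc1` has phenyl in place of methyl on a nitrogen on an aromatic ring, a change from methylamino to anilino (phenyl in place of methyl on a nitrogen on an aromatic ring). The expected result in this assay is a modest move toward stronger inhibition, an at least 2.0-fold lower number from compound 2 to compound 3 (0.30 log units; that floor lies within the scatter), and this is only a rough guess, and another limit is quite possible. Compound 3 is estimated at 500000 nM, with an expected range from 50000 nM to 2000000 nM.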

Compound 3, half-maximal inhibitory concentration: > 1000000 nM
Compound 3: only a limit was reported (the forecaster's own chance of this, stated with the estimate: 60%); at least 2.0-fold (0.30 log units) between middle value and limit.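

Compound 2 and compound 3 both carry only a limit in this assay, and the step between them cannot be read. The compounds shown leave open whether anilino in place of methylamino changes inhibition at all and, if it does, in which direction and by how much.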